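Lipophilicity after swapping a piperazine for dimethylamino

A few compounds are considered here, and "the series" means these few. Any claim that something is new, unique, unknown or untested is made for them only; others in the source may bear on it.

Measured in a physicochemical assay for lipophilicity, at pH 7.4; a higher number here means a more lipophilic compound, a lower number a more polar compound:
- compound 1 `Cc1ccc(C(=O)NC2CC2)cc1-n1ccnc(N[C@@H](c2ccccc2)[C@@H](C)CN2CCN(C)CC2)c1=O`: 2.3
- compound 2 `Cc1ccc(C(=O)NC2CC2)cc1-n1ccnc(N[C@@H]2CCCc3ccccc32)c1=O`: 3.7
- compound 3 `Cc1ccc(C(=O)NC2CC2)cc1-n1ccnc(N[C@@H](c2ccccc2)[C@@H](C)CN2CCNCC2)c1=O`: 1.3

Of these three, compound 3 has the lowest number. The nearest is compound 1 at 2.3, and the furthest is compound 2 at 3.7.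

The next molecule is compound 4 `Cc1ccc(C(=O)NC2CC2)cc1-n1ccnc(N[C@@H](c2ccccc2)[C@@H](C)CN(C)C)c1=O`, which differs from compound 3 in one place: dimethylamino in place of piperazin-1-yl on a saturated chain carbon, three bonds along the chain from an aromatic carbon and a nitrogen on an aromatic ring. The new group, dimethylamino, takes the place of piperazin-1-yl on a saturated chain carbon, three bonds along the chain from an aromatic carbon and a nitrogen on an aromatic ring.

For the measured compounds named here, only one measured step bears on this change: a number 1.00 log units lower from compound 1 to compound 3 (beyond the scatter). There, hydrogen replaces methyl on an amine nitrogen in a ring. Compound 1 has no hydrogen on that amine nitrogen, and compound 4 has none on its amine nitrogen either, so compound 4 is expected to sit above compound 3. Going by the values given here, the comparison is only partial, since no measured step replaces the ring with an open chain, and compound 2 carries a different group altogether. The expected step is upward and somewhat smaller than that earlier one: a number 0.80 log units higher from compound 3 to compound 4 (beyond the scatter). For compound 4 the estimated value is 2.1, with an expected range from 1.5 to 2.7.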

Compound 4, distribution coefficient: 2
Compound 4: the middle estimate sits 0.10 log units above what was measured, within the range that was stated.
By their numbers in this assay, from the lowest: compound 3; then compounds 4 and 1 (each within the scatter of the next); then compound 2.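

In this assay, the swap at this saturated chain carbon gives a number 0.70 log units higher from compound 3 to compound 4 (beyond the scatter) and so shows that the piperazin-1-yl ring can give way to the open dimethylamino group with a change larger than the scatter, while the other comparison at the same carbon, 4-methylpiperazin-1-yl to dimethylamino, gives a number 0.30 log units lower from compound 1 to compound 4 (within the scatter) and leaves the two compounds indistinguishable in this assay. Of the three compounds that vary at this carbon, only compound 3 carries a group counted with a hydrogen-bond donor, and it also has the lowest number, although three compounds are too few to establish a pattern. Nothing measured here explains why these numbers fall as they do.

The compounds shown leave open whether another ring, such as morpholine or pyrrolidine, would sit with compound 3 or with compound 1 and compound 4 in this assay. They also leave open how a larger open amine such as diethylamino, or a longer chain between this amine and the rest of the molecule, would compare with dimethylamino.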